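A Cyanobutyl Chain Added to a Well-Tolerated Core

A few compounds are considered here, and "the series" means these few. Any claim that something is new, unique, unknown or untested is made for them only; others in the source may bear on it.

Compound 1 `CN1C(=S)[C@@H](NC(=O)c2n[nH]c(Cc3ccccc3)n2)COc2ccccc21` gives > 50000 nM in a toxicity assay on HT-29 cells (Homo sapiens) for cytotoxicity; a higher number here means that more compound is tolerated, a lower number that less compound is tolerated.
Compound 2 `CCCCCn1nc(C(=O)N[C@H]2COc3ccccc3N(C)C2=S)nc1Cc1ccccc1` gives > 100000 nM in this assay.

Both of these readings are limits of the assay, not numbers. For the measured compounds named here, compound 1 stands at a limit, and the only other value shown is a limit as well, so the position of compound 1 within the range of this assay cannot be placed any more closely. The step that the two limits leave unreadable from compound 1 to compound 2 is accordingly unreadable because the limit of > 100000 nM in this assay, at which 1 of the 2 values shown sits, and the limit of > 50000 nM in this assay, at which 1 of the 2 values shown sits, sit at its two ends. Going by the values given here, compound 3 `CN1C(=S)[C@@H](NC(=O)c2nc(Cc3ccccc3)n(CCCCC#N)n2)COc2ccccc21` carries 4-cyanobutyl in place of hydrogen on an aromatic nitrogen, a change that resembles the one made in compound 2 apart from the end of the chain. Among the compounds with values here, no measured step bears readably on this change; the one comparable step gave no size at all. Compound 3 is therefore expected to remain at or beyond the limit, with a step that the limit leaves unreadable from compound 1 to compound 3 that is itself expected to stay unreadable. The estimate for compound 3 is 100000 nM, ranging from 30000 nM to 300000 nM.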

Compound 3, half-maximal cytotoxic concentration: > 100000 nM
Compound 3: only a limit was reported (the forecaster's own chance of this, stated with the estimate: 85%); the middle value lies on the limit itself.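

In this assay, for the compounds shown here, compound 3 gives > 100000 nM, which is a limit and not a number, and no step from compound 1 or compound 2 to compound 3 can be read. The compounds shown leave open whether the 4-cyanobutyl and pentyl chains differ at all in this assay.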